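A few compounds are considered here, and "the series" means these few. Any claim that something is new, unique, unknown or untested is made for them only; others in the source may bear on it.

Within the data shown here, compound 1 `CC(=O)c1ccc(NC(=O)C(CC(C)C)N(C(=O)c2ccccc2)S(=O)(=O)c2ccc(C)cc2)cc1` is the stronger of the two compounds measured so far. In a functional assay for inhibition, read by spectrophotometry, with a stated time of 20 min, tested at 5 mg/mL (on this read-out lower numbers stand for a weaker effect and higher numbers for a stronger effect at the one concentration tested), compound 1 gives 71.3%, the highest of the two numbers. Among the measured compounds shown here, its only neighbour, compound 2 `CC(=O)c1ccc(NC(=O)C(C(C)C)N(C(=O)c2ccccc2)S(=O)(=O)c2ccc(C)cc2)cc1`, carries an isopropyl in place of the isobutyl on the saturated chain carbon bound to an amide-type nitrogen and a carbonyl carbon. In this assay compound 2 gives 42.7%. The step that separates them is clear: a number 28.6 percentage points lower from compound 1 to compound 2 (beyond the scatter).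

Compound 3 `CC(=O)c1ccc(NC(=O)C(CC(C)C)N(C(=O)c2ccccc2)S(=O)(=O)c2ccc([N+](=O)[O-])cc2)cc1` keeps the isobutyl chain of compound 1 and differs elsewhere: nitro in place of methyl on an aromatic carbon. For the measured compounds named here, the change sits on an aromatic carbon of the six-membered aromatic ring of carbon only, para to a large group, so none of the measured steps bears on it; the one measured step concerns the chain, not this ring. With nothing to point either way, the number for compound 3 is expected to stay near that of compound 1, and a number 6.3 percentage points lower from compound 1 to compound 3 (within the scatter) is the estimated step, one that need not go beyond the scatter. The estimate for compound 3 in this assay is 65%, expected to fall between 40% and 88%.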

Compound 3, a percentage reported as inhibition, at one concentration (the size of the read-out at that concentration, not a potency): 81.3%
The estimate for compound 3 lay 16.3 percentage points below the measured number; the range from low to high includes it.
By their numbers in this assay, from the lowest: compound 2; then compounds 1 and 3 (each within the scatter of the next).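

In this assay, nitro in place of methyl on the aromatic carbon gives a number 10 percentage points higher from compound 1 to compound 3 (within the scatter), so at this position three heavy atoms with two hydrogen-bond acceptors can stand in place of a single carbon without the reading moving beyond the scatter. Among these compounds, the earlier pair spoke only of the chain, where isopropyl in place of isobutyl gave a number 28.6 percentage points lower from compound 1 to compound 2 (beyond the scatter); this pair is the first look at the aromatic ring of the sulfonyl group, and so far the chain is the only place where a single change has gone beyond the scatter. No measurement at hand says what lies behind this result.

The compounds shown leave open whether an amine or a carboxylic acid on this same aromatic carbon would also stay within the scatter of compound 1, or whether a group of that kind would mark a limit to what the position tolerates. They also leave open whether nitro in place of methyl would give a similar step when paired with the isopropyl chain of compound 2.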